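Methyl on the core: a step with no measured precedent

This account rests on a few compounds, and the source may have more. Where it says the series, first, only, none or still open, it means among the compounds named here.

Measured so far:
- Compound 1, `CC/N=C(/NC#N)NCCCCn1nc(-c2ccccc2)ccc1=O`, gives 92 mg/kg in a functional assay on the whole organism (stomach) with Rattus norvegicus as the target; on this read-out lower numbers stand for an effect already at smaller amounts and higher numbers for an effect only at larger amounts of compound.
- Compound 2, `C/N=C(/NC#N)NCCCCCn1nc(-c2ccccc2)ccc1=O`, gives 100 mg/kg in this assay.
- Compound 3, `C/N=C(/NC#N)NCCCCCn1nc(-c2ccccc2)c(C)cc1=O`, is not yet measured.

Compound 2 has the highest of the two numbers, and its nearest neighbour is compound 1: the difference between them, a 1.1-fold higher number from compound 1 to compound 2 (0.04 log units; within the scatter), lies within the scatter, so the two cannot be told apart. That one step exchanged the tail on the saturated chain; it says nothing about the ring of the shared core.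

Compound 3 differs from compound 2 by methyl in place of hydrogen on an aromatic carbon. Within the data shown here, no measured step touches that ring position, so there is no direct precedent. Among the measured compounds shown here, the only step known, from compound 1 to compound 2, was within the scatter and concerns a different part of the molecule; it gives no reason to expect a move in either direction. The expectation is therefore a step of no change at the digits printed from compound 2 to compound 3 (within the scatter), that is none beyond the scatter. Compound 3 is estimated at 100 mg/kg, with a range of 40 mg/kg to 250 mg/kg.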

Compound 3, dose for half-maximal effect: > 100 mg/kg
Compound 3 ended at the assay's limit; the forecaster's own chance of this, stated with the estimate: 10%; the middle value lies on the limit itself.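

In this assay compound 3 gives > 100 mg/kg, which is a limit of the assay and not a number. Methyl in place of hydrogen on this aromatic carbon, a ring position that no earlier step had touched, gives a number no lower from compound 2 to compound 3 (the limit leaves the size open), so the change brought no lower number, but the size of the step cannot be read. This position therefore shows no sign of a gain from methyl on this read-out, and whether the change left the number where it was or raised it stays undecided: the limit of > 100 mg/kg in this assay, at which 1 of the 3 values shown sits.

On these data alone, whether another group on this same aromatic carbon, such as an ethyl group, a chlorine atom or an amine, would give a number that can be read remains open. It is also open whether methyl at this position would give the same outcome when combined with the tail of compound 1, since the only compound shown with this methyl carries the tail of compound 2.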